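This account rests on a few compounds, and the source may have more. Where it says the series, first, only, none or still open, it means among the compounds named here.

In a functional assay on HEK293 cells for antagonist activity at metabotropic glutamate receptor 5 (Homo sapiens), read by FLIPR and calcium flux (on this read-out higher numbers stand for weaker inhibition and lower numbers for stronger inhibition), compound 1 `CN(C)c1ccc(C(=O)N[C@H]2CCC[C@H](NC(=O)c3cccc(Cl)c3)C2)cc1` gives 473 nM. Compound 2 `N#Cc1cccc(C(=O)N[C@H]2CCC[C@H](NC(=O)c3ccccn3)C2)c1` does not reach a number in this assay: its result is the limit of > 10000 nM, where one of the two values stands (the limit of > 10000 nM in this assay, at which 1 of the 2 values shown sits). Compound 3 `O=C(N[C@H]1CCC[C@H](NC(=O)c2ccccn2)C1)c1cccc(Cl)c1` keeps the shared core and differs from compound 2 by chloro in place of cyano on an aromatic carbon. Going by the values given here, no measured pair shows this exact change, so the expected step of an at least 2.8-fold lower number from compound 2 to compound 3 (0.45 log units; beyond the scatter) is a modest gain in inhibition, a little beyond the usual scatter. Compound 3 is estimated near 3500 nM, within 900 nM to 12000 nM.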

Compound 3, half-maximal inhibitory concentration: > 10000 nM
Compound 3: only a limit was reported (the forecaster's own chance of this, stated with the estimate: 35%); at least 2.8-fold (0.45 log units) between middle value and limit.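

Compound 2 and compound 3 each give only a limit, so the step between them cannot be read: the limit of > 10000 nM in this assay, at which 2 of the 3 values shown sit. Compound 3 does show something new: with the 3-chlorophenyl side kept, pyridin-2-yl in place of 4-(dimethylamino)phenyl brings an at least 21-fold higher number from compound 1 to compound 3 (1.32 log units; beyond the scatter), so the 3-chlorophenyl group alone does not secure measurable inhibition here.

As far as these compounds go, whether chloro and cyano differ at all remains open, as neither has been compared on a partner that gives a number. Also open, from the compounds shown here alone, is whether a plain phenyl or a 4-methoxyphenyl on that carbonyl carbon would restore inhibition.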